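This account rests on a few compounds, and the source may have more. Where it says the series, first, only, none or still open, it means among the compounds named here.

The study reports two measured compounds in a functional assay on CHO cells for agonist activity at Free fatty acid receptor 1 (Homo sapiens); on this read-out lower numbers stand for an effect already at smaller amounts and higher numbers for an effect only at larger amounts of compound. Compound 1, `Cc1nc(-c2ccc(C(F)(F)F)cc2)sc1CNc1ccc(CC(=O)O)cc1`, is known only to a limit of the assay: in this assay compound 1 gives < 10000 nM, which is a limit and not a number. Compound 2, `CC(C)NC(=O)CCc1ccc(NCc2cccc(Oc3ccccc3)c2)cc1`, has a measured value, and in this assay compound 2 gives 39.8 nM. Among the compounds with values here, no step between measured compounds that differ in one place is available, so the account turns to the unmeasured compound 3, `Cc1nc(-c2ccc(C(F)(F)F)cc2)sc1CNc1ccc([C@H]2C[C@@H]2C(=O)NC2CCNC2)cc1`, which differs from compound 1 by 2-((pyrrolidin-3-yl)carbamoyl)cyclopropyl in place of carboxymethyl on an aromatic carbon. Because the limit of < 10000 nM in this assay, at which 1 of the 2 values shown sits, is all that is known of compound 1, the direction of the step cannot be read from a number. The change is large, and a step beyond the scatter is expected, with its direction open. Compound 3 is expected to give 1000 nM, within a range of 100 nM to 10000 nM. That estimate corresponds to an expected step that the limit leaves unreadable from compound 1 to compound 3.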

Compound 3, half-maximal effective concentration: 204 nM
Compound 3: middle estimate off by 4.9-fold (0.69 log units), on the high side; the range from low to high includes it.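

No new step can be read between compound 1 and compound 3, because compound 1 is known only by a limit: the limit of < 10000 nM in this assay, at which 1 of the 3 values shown sits.

The compounds shown leave open in which direction, and how far, 2-((pyrrolidin-3-yl)carbamoyl)cyclopropyl in place of carboxymethyl shifts the value in this assay.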